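Aryl Hydrazone Variation on a Shared Core

The source may hold more compounds than are shown below. What is called first, only, known or untested is meant among the compounds shown, and "the series" means these compounds.

Measured so far:
Compound 1 `Cc1cccc(/C=N/Nc2ncc3c(n2)n(C2CCCC2)c(=O)c(=O)n3C)c1` gives 34500 nM.
Compound 2 `Cn1c(=O)c(=O)n(C2CCCC2)c2nc(N/N=C/c3ccc(F)c(Cl)c3)ncc21` gives 9410 nM.

Both numbers come from a functional assay on A549 cells (Homo sapiens) for antiproliferative activity, read by MTT assay; on this read-out higher numbers stand for weaker inhibition and lower numbers for stronger inhibition. Among the two measured compounds, compound 2 holds the lower number, and the step of a 3.7-fold lower number from compound 1 to compound 2 (0.56 log units; beyond the scatter) separates it from compound 1, so compound 2 is the stronger inhibitor of the pair.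

Compound 3 `Cn1c(=O)c(=O)n(C2CCCC2)c2nc(N/N=C/c3ccc(O)c(F)c3)ncc21` has not yet been measured in this assay. It differs from compound 2 in one place: 3-fluoro-4-hydroxyphenyl in place of 3-chloro-4-fluorophenyl on a carbon with a double bond to nitrogen.

Among the compounds with values here, only one measured step exists, a 3.7-fold lower number from compound 1 to compound 2 (0.56 log units; beyond the scatter), and it concerns a different exchange on the same carbon, so it does not speak directly to a hydroxyl entering the ring. Within the data shown here, no measured pair here shows what a hydroxyl does. The change therefore cannot be anchored to a shown step, and the expectation is that compound 3 stays close to compound 2, with a step of a 1.6-fold higher number from compound 2 to compound 3 (0.20 log units; within the scatter) that may well fall within the scatter. The estimate for compound 3 in this assay is 15000 nM, with a range from 5000 nM to 45000 nM.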

Compound 3, half-maximal inhibitory concentration: 97800 nM
Compound 3: middle estimate off by 6.5-fold (0.81 log units), on the low side, and the stated range ends below it.
By their numbers in this assay, from the lowest: compound 2; then compound 1; then compound 3.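

In this assay, the aryl group on the carbon with a double bond to nitrogen can shift the number much further than the first exchange suggested: 3-fluoro-4-hydroxyphenyl in place of 3-chloro-4-fluorophenyl gives a 10-fold higher number from compound 2 to compound 3 (1.02 log units; beyond the scatter), a large step where the earlier one, a 3.7-fold lower number from compound 1 to compound 2 (0.56 log units; beyond the scatter), was modest. The same group also compares poorly with 3-methylphenyl, with a 2.8-fold higher number from compound 1 to compound 3 (0.45 log units; beyond the scatter), so compound 3 is the weakest inhibitor of the three, and a ring with a hydroxyl ranks behind both rings without one in this small set. This exchange brings in a hydrogen-bond donor and a hydrogen-bond acceptor where 3-chloro-4-fluorophenyl has neither, but nothing available here explains the rise in the number.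

The step from compound 2 to compound 3 removes the chlorine and adds the hydroxyl at once, so how much each change contributes remains unsettled. On these data alone, it is also open whether a methoxy group, which keeps the oxygen but not the hydroxyl hydrogen, or an amine on the same ring would behave like the hydroxyl.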